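The compounds below may be only part of what the source reports. "The series", "measured", "known", "first", "only" and "open" are said of these compounds alone.

Three compounds share one core and differ only in the substituent on the benzyl ring attached through sulfur. Compound 1 `OC[C@H]1O[C@@H](n2cnc3c(SCc4cccc(Cl)c4)ncnc32)[C@H](O)[C@@H]1O` gives 18.2 nM in an assay on isolated protein for inhibition of Equilibrative nucleoside transporter 1 (Homo sapiens); on this read-out higher numbers stand for weaker inhibition and lower numbers for stronger inhibition. Compound 2 `N#Cc1cccc(CSc2ncnc3c2ncn3[C@@H]2O[C@H](CO)[C@@H](O)[C@H]2O)c1` gives 36.3 nM in this assay, and compound 3 `Cc1cccc(CSc2ncnc3c2ncn3[C@@H]2O[C@H](CO)[C@@H](O)[C@H]2O)c1` gives 16.2 nM in this assay. Compound 3 holds the lowest of the three numbers, yet the step of a 1.1-fold lower number from compound 1 to compound 3 (0.05 log units; within the scatter) lies within the scatter, so compound 1 is not separated from it; compound 2 is set apart by a 2.2-fold lower number from compound 2 to compound 3 (0.35 log units; beyond the scatter) and by a 2.0-fold higher number from compound 1 to compound 2 (0.30 log units; within the scatter).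

Compound 4 `Cc1ccc(CSc2ncnc3c2ncn3[C@@H]2O[C@H](CO)[C@@H](O)[C@H]2O)cc1` differs from compound 3 in one place: 4-methylphenyl in place of 3-methylphenyl on a saturated chain carbon bound to a sulfur. For the measured compounds named here, none of the measured steps is of this kind. Each of them swaps one group for another at the same aromatic carbon, chloro to cyano, chloro to methyl, cyano to methyl, while the methyl group of compound 3 is retained in compound 4 and only its position on the ring moves. Going by the values given here, no measured step therefore bears directly on this change, and there is no basis for expecting a shift beyond the scatter in this assay in either direction. The number for compound 4 is expected to stay close to that of compound 3, with a 1.0-fold lower number from compound 3 to compound 4 (0.01 log units; within the scatter) estimated to remain within the scatter. Compound 4 is estimated at 16 nM, with a range from 7 nM to 40 nM.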

Compound 4, inhibition constant: 15.1 nM
For compound 4 the middle estimate is 1.1-fold (0.03 log units) above the measured one; low and high end bracket the measured number.
By their numbers in this assay, from the lowest: compounds 4, 3, 1 and 2 (each within the scatter of the next, the first and the last beyond it).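

Going from 3-methylphenyl to 4-methylphenyl on a saturated chain carbon bound to a sulfur gives a 1.1-fold lower number from compound 3 to compound 4 (0.03 log units; within the scatter) in this assay and is the first change in the series that keeps the group and alters only where it sits on the ring; that change is not resolved in this assay. For the compounds shown here, the gap to the nitrile compound is seen again with the 4-methylphenyl group, at a 2.4-fold lower number from compound 2 to compound 4 (0.38 log units; beyond the scatter) in this assay, while a 1.2-fold lower number from compound 1 to compound 4 (0.08 log units; within the scatter) leaves the chloro compound unseparated, so 3-cyanophenyl remains the only group set apart from a methylphenyl group, and compound 1 still is not. No accompanying measurement offers an explanation for any of these steps.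

As far as these compounds go, only methyl is seen in both ring placements, so it remains open whether 4-chlorophenyl or 4-cyanophenyl would track their 3-substituted counterparts in the way 4-methylphenyl tracks 3-methylphenyl. Also open, from the compounds shown here alone, is how the read-out responds to an amine or a carboxylic acid on the ring, or to a longer chain in place of the methyl group.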